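A few compounds are considered here, and "the series" means these few. Any claim that something is new, unique, unknown or untested is made for them only; others in the source may bear on it.

Measured compounds:
Compound 1, `COc1ccc(C2N=C(SCc3ccc(Cl)cc3)NC(C)=C2C(=O)Nc2ccc(F)cc2)cc1OC`, gives 20% in a functional assay on the whole organism (artery, strain albino) with Rattus norvegicus as the target, with a stated time of 900 min, at a dose of 10 mg/kg by the oral route; a higher number here means more inhibition at the dose given (going by the name of the read-out), a lower number less inhibition.
Compound 2, `CC1=C(C(=O)Nc2ccc(F)cc2)C(c2ccc([N+](=O)[O-])cc2)N=C(SCc2cccc(Cl)c2)N1`, gives 10.8% in this assay.

Compound 2 stands lowest of the two numbers measured in this assay; its nearest neighbour is compound 1, whose value lies higher by an amount within the usual scatter of repeated measurements, so the two cannot be told apart on these numbers. Compound 3, `CC1=C(C(=O)Nc2ccc(F)cc2)C(c2ccc([N+](=O)[O-])cc2)N=C(SCc2ccc(Cl)cc2)N1`, has not yet been measured. It differs from compound 2 in one place: 4-chlorophenyl in place of 3-chlorophenyl on a saturated chain carbon bound to a sulfur. The two compounds hold the same atoms, joined differently. For the measured compounds named here, no pair of measured compounds differing in a single place is available, so nothing among the known numbers says how this particular change acts on its own. Compound 1 also carries 4-chlorophenyl on a saturated chain carbon bound to a sulfur, yet its other aromatic ring is different, so its value cannot be read as the effect of this change alone. The expected step from compound 2 to compound 3 is a number 3.2 percentage points higher from compound 2 to compound 3 (within the scatter), which amounts to no movement beyond the scatter. Compound 3 is therefore estimated at 14%, with a range from 0% to 30%.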

Compound 3, a percentage reported as inhibition, in the whole organism at one dose (the size of the read-out at that dose, not a potency): 16.9%
Estimate against measurement, compound 3: 2.9 percentage points below; measured number inside the range.
By their numbers in this assay, from the lowest: compounds 2, 3 and 1 (each within the scatter of the next).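

In this assay, for the compounds shown here, 4-chlorophenyl in place of 3-chlorophenyl on a saturated chain carbon bound to a sulfur gives a number 6.1 percentage points higher from compound 2 to compound 3 (within the scatter), the first direct reading of this change on its own: the two compounds hold the same atoms, and this rearrangement produces no difference that can be separated from repeat-measurement noise. The other new comparison, 4-nitrophenyl in place of 3,4-dimethoxyphenyl on a saturated ring carbon, gives a number 3.1 percentage points lower from compound 1 to compound 3 (within the scatter), so on these numbers that exchange of rings cannot be told apart from no change either, and all three compounds sit within the scatter of their neighbours. No measured property of these compounds bears on these results.

Going by these compounds alone, both readings come from a single oral dose, so they give the size of the inhibition at that dose and say nothing about potency, and only two kinds of ring exchange are covered. Going by these compounds, what stays open is whether a more different group on the saturated chain carbon bound to a sulfur, such as an amine, a carboxylic acid or a longer chain in place of the chlorophenyl ring, would move the number beyond the scatter.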